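Benzyl for dichlorophenyl on the amide nitrogen

The source may report more compounds than this note shows. Statements on the series, on what has been measured and on what is new or still open speak of the compounds shown alone.

Three compounds sharing one core were run in an ADME assay on BHK-21 cells (Mesocricetus auratus) for cytotoxicity, with a stated time of 3 days; a higher number here means that more compound is tolerated, a lower number that less compound is tolerated:

compound 1, `CC(Sc1nnc(-c2ccncc2)s1)C(=O)NCc1ccccc1Cl`, gives > 50000 nM, a limit of the assay
compound 2, `CC(Sc1nnc(-c2ccncc2)s1)C(=O)Nc1c(Cl)cccc1Cl`, gives > 50000 nM, also a limit
compound 3, `O=C(CSc1nnc(-c2ccncc2)s1)Nc1c(Cl)cccc1Cl`, gives "not determined" (no result reported).

The value of compound 1 is only a limit. The value of compound 2 is likewise only a limit. Compound 3 therefore stands without a number of its own, and the two values beside it are both limits. Within the data shown here, the one step among the measured compounds, a step that the two limits leave unreadable from compound 1 to compound 2, runs between two limits and its size cannot be read.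

Compound 4, `O=C(CSc1nnc(-c2ccncc2)s1)NCc1ccccc1`, is the next compound and has not yet been measured in this assay. Its difference from compound 3 is benzyl in place of 2,6-dichlorophenyl on an amide-type nitrogen. Among the measured compounds shown here, no measured step reports a benzyl entering in place of a 2,6-dichlorophenyl on an amide-type nitrogen, and the only step at hand is unreadable, so no direction and no size beyond the scatter can be expected from the data. What the data do show is the limit of > 50000 nM in this assay, at which 2 of the 3 values shown sit.

Compound 4 is therefore estimated at 50000 nM in this assay, most likely reported again as a limit, with a range from 25000 nM to 100000 nM.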

Compound 4, half-maximal cytotoxic concentration: 11300 nM
Estimate against measurement, compound 4: 4.4-fold (0.65 log units) above; the whole stated range lies above it.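

Among these compounds, compound 3 has no reported result in this assay, so no step from it to compound 4 can be read, and compound 4 stands with a number of its own but no readable partner. The compounds shown leave open how benzyl in place of 2,6-dichlorophenyl on an amide-type nitrogen shifts the tolerated concentration in this assay.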